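A few compounds are considered here, and "the series" means these few. Any claim that something is new, unique, unknown or untested is made for them only; others in the source may bear on it.

Working notes on the series. Three compounds carry results in an ADME assay on HeLa cells (Homo sapiens) for cytotoxicity, read by MTT assay, with a stated time of 24 h; on this read-out lower numbers stand for stronger inhibition and higher numbers for weaker inhibition. Compound 1 `CN(C)C(=S)SC(=S)N1CCCC1` gives 3090000 nM. Compound 3 `CN1CCN(C(=S)SC(=S)N(C)C)CC1` gives 1220000 nM, the lowest of the two numbers shown; compound 1 sits higher, and the gap between them lies beyond the scatter. Compound 2 `CN(C)C(=S)SC(=S)N1CCCCCC1` gives only a limit in this assay, > 5000000 nM; this is the limit of > 5000000 nM in this assay, at which 1 of the 3 values shown sits, a limit and not a number. Within the data shown here, no pair of measured compounds differs in a single place, so no measured step can be quoted for the series.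

Compound 4 `CCSC(=S)N1CCN(C(=S)SC(=S)N(C)C)CC1` is the next in line, not yet measured in this assay. It differs from compound 3 in one place: a group of 5 heavy atoms (3 carbon, 2 sulfur; no ring) in place of one carbon atom, on an amine nitrogen in a ring. Among the measured compounds shown here, none of the measured compounds speaks to a change of this kind, so only a modest step is expected. The step expected a 1.5-fold lower number from compound 3 to compound 4 (0.18 log units; within the scatter) points to a somewhat lower number, close to the scatter. Compound 4 is accordingly estimated at 800000 nM, with a range from 250000 nM to 2500000 nM, and the measurement is awaited.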

Compound 4, half-maximal inhibitory concentration: 4480000 nM
The estimate for compound 4 lay 5.6-fold (0.75 log units) below the measured number, and the stated range ends below it.
By their numbers in this assay, from the lowest: compound 3; then compounds 1 and 4 (each within the scatter of the next). At a limit, above all of these: compound 2.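

In this assay, among these compounds, replacing the methyl on the amine nitrogen in the ring with a group of 5 heavy atoms (3 carbon, 2 sulfur; no ring) gives a 3.7-fold higher number from compound 3 to compound 4 (0.56 log units; beyond the scatter), the only single-place step. Among the compounds shown here, this position therefore responds to substitution, and this change moves the read-out towards weaker inhibition, which the earlier compounds, none differing from another in one place, could not show. No measured property bears on this step, and the data offer no explanation for it.

With only one change shown at this nitrogen, a single step fixes no trend with the size or kind of group. Going by these compounds, whether an ethyl, an acetyl or a bare amine hydrogen at this nitrogen would hold the number of compound 3 stays open.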